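Benzyl to tert-butyl on the amide nitrogen of compound 2

This account rests on a few compounds, and the source may have more. Where it says the series, first, only, none or still open, it means among the compounds named here.

Compound 1 `C=CC1=C(C(=O)NCc2ccccc2)C(c2ccc(OC)c(OC)c2)OC1` carries a benzyl group on its amide nitrogen. In a functional assay on HeLa cells (Homo sapiens) for cytotoxicity, read by MTT assay, with a stated time of 24 h (a lower number here means a stronger inhibitor, a higher number a weaker inhibitor), compound 1 reaches only the limit of > 100000 nM. Compound 2 `C=CC1=C(C(=O)NCc2ccccc2)C(c2ccc(OC)cc2)OC1` differs by hydrogen in place of methoxy on an aromatic carbon. In this assay compound 2 likewise sits at the limit of > 100000 nM. The step that the two limits leave unreadable from compound 1 to compound 2 cannot be read, since both ends rest on (the limit of > 100000 nM in this assay, at which 2 of the 3 values shown sit). Going by the values given here, compound 3 `C=CC1=C(C(=O)O)C(c2ccc(F)cc2)OC1`, a carboxylic acid rather than an amide, gives 67400 nM in this assay, and no single-point step connects it to compound 2.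

Compound 4 `C=CC1=C(C(=O)NC(C)(C)C)C(c2ccc(OC)cc2)OC1` is the next member: tert-butyl in place of benzyl on an amide-type nitrogen. Among the compounds with values here, no measured step touches the amide nitrogen, so the only bearing evidence is the limit of compound 2 and the unreadable step from compound 1. Nothing shown suggests that compound 4 should move away from that limit. The expected step that the limit leaves unreadable from compound 2 to compound 4 is therefore none beyond the scatter. Compound 4 is estimated at 150000 nM, with a range from 50000 nM to 500000 nM, most likely reported again only as a limit.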

Compound 4, half-maximal inhibitory concentration: > 100000 nM
Compound 4 ended at the assay's limit; the forecaster's own chance of this, stated with the estimate: 80%; the middle value lies beyond the limit too.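

In this assay compound 4 gives > 100000 nM, which is a limit. No step can be read between compound 2 and compound 4, as both rest on limits: the limit of > 100000 nM in this assay, at which 3 of the 4 values shown sit.

The compounds shown leave open whether benzyl and tert-butyl on the amide nitrogen differ at all in cytotoxicity.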